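From 2-chlorobenzyl to 3,4-dichlorobenzyl: an untested step

The source may report more compounds than this note shows. Statements on the series, on what has been measured and on what is new or still open speak of the compounds shown alone.

Three compounds measured in a functional assay on MDA-MB-231 cells (Homo sapiens) for cytotoxicity, read by MTT assay, with a stated time of 72 h (a lower number here means a stronger inhibitor, a higher number a weaker inhibitor), give these values
compound 1 (`CN(C)Cc1ccc2nc(NC(=O)N/N=C/c3cn(Cc4ccccc4Cl)c4ccccc34)sc2c1`) at 1180 nM
compound 2 (`CC1CCN(Cc2ccc3nc(NC(=O)N/N=C/c4cn(Cc5ccccc5Cl)c5ccccc45)sc3c2)CC1`) at 1360 nM
compound 3 (`CCN(CC)Cc1ccc2nc(NC(=O)N/N=C/c3cn(Cc4ccccc4Cl)c4ccccc34)sc2c1`) at 900 nM

Compound 1 cannot be told apart from the other two in this assay on these numbers. Its two steps are a 1.2-fold higher number from compound 1 to compound 2 (0.06 log units; within the scatter) and a 1.3-fold lower number from compound 1 to compound 3 (0.12 log units; within the scatter) and the remaining pair shows a 1.5-fold lower number from compound 2 to compound 3 (0.18 log units; within the scatter) so all three values lie within the usual scatter of one another. Each of these steps exchanges only the amino group on a saturated chain carbon bound to an aromatic carbon.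

Compound 4 (`CN(C)Cc1ccc2nc(NC(=O)N/N=C/c3cn(Cc4ccc(Cl)c(Cl)c4)c4ccccc34)sc2c1`) keeps the dimethylamino group of compound 1 and differs at another place. The difference is 3,4-dichlorophenyl in place of 2-chlorophenyl on a saturated chain carbon bound to an aromatic nitrogen and it sits on a saturated chain carbon bound to an aromatic nitrogen. Going by the values given here, no measured step touches this place, so the data give no direct guide to the size or direction of this change. The expectation therefore starts from compound 1 at 1180 nM and assumes no step beyond the scatter, while allowing a wide margin on both sides. In this assay the estimated change is a 1.2-fold lower number from compound 1 to compound 4 (0.07 log units; within the scatter) and it is expected to stay within the scatter. Compound 4 is expected at 1000 nM with an estimated range of 400 nM to 2500 nM and no limit reading is anticipated.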

Compound 4, half-maximal inhibitory concentration: 1000 nM
The estimate for compound 4 equals the measured number at the digits printed, and the stated range covers the measured number.
By their numbers in this assay, from the lowest: compounds 3, 4, 1 and 2 (each within the scatter of the next).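

Until now every compound carried the 2-chlorobenzyl group and only the amino group changed, so the data said nothing about this part of the molecule. In this assay, placing 3,4-dichlorophenyl in place of 2-chlorophenyl on a saturated chain carbon bound to an aromatic nitrogen gives a 1.2-fold lower number from compound 1 to compound 4 (0.07 log units; within the scatter), so this first change at the new place, like the amino exchanges, produces no difference that can be told from ordinary measurement scatter. Going by these compounds alone, nothing measured here explains that outcome, and the single step adds a chlorine and changes the chlorine pattern at once, so the two changes cannot be separated.

A 3-chlorobenzyl or 4-chlorobenzyl group would help to separate those two changes, while a plain benzyl group would show how the number reads with no chlorine at all. Going by these compounds, it also remains open whether the number would hold with a carboxylic acid on this phenyl ring, with a longer chain such as 2-phenylethyl at this place, or with 3,4-dichlorobenzyl paired with the diethylamino group of compound 3.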